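This account rests on a few compounds, and the source may have more. Where it says the series, first, only, none or still open, it means among the compounds named here.

Compound 1 `Cc1cc(-c2ccccc2)n(/C(N)=N/S(=O)(=O)c2cc(C)c(Cl)cc2SCc2ccccc2C)n1` gives 42000 nM in a functional assay on HCT-116 cells (Homo sapiens) for cytotoxicity, read by MTT assay, with a stated time of 72 h (a higher number here means a weaker inhibitor, a lower number a stronger inhibitor), and so stands at the highest of the two numbers in hand. Compound 2 `Cc1cc(S(=O)(=O)/N=C(\N)n2nccc2-c2ccccc2)c(SCc2ccccc2C)cc1Cl` gives 16000 nM, the step of a 2.6-fold lower number from compound 1 to compound 2 (0.42 log units; beyond the scatter) arising from hydrogen in place of methyl on an aromatic carbon. Compound 3 `Cc1cccc(CSc2cc(Cl)c(C)cc2S(=O)(=O)/N=C(\N)n2nc(C)cc2-c2ccccc2)c1` carries 3-methylphenyl in place of 2-methylphenyl on a saturated chain carbon bound to a sulfur. For the measured compounds named here, no measured step touches the (2-methylbenzyl)sulfanyl part, so there is nothing to bear on this change, and no step beyond the scatter is expected in this assay. For compound 3 the expected value is 42000 nM, range 18000 nM to 95000 nM, meaning an estimated step of no change at the digits printed from compound 1 to compound 3 (within the scatter).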

Compound 3, half-maximal inhibitory concentration: 34000 nM
Estimate against measurement, compound 3: 1.2-fold (0.09 log units) above; measured number inside the range.
By their numbers in this assay, from the lowest: compound 2; then compounds 3 and 1 (each within the scatter of the next).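

For the compounds shown here, this is the first measured change on the saturated chain carbon bound to a sulfur: in this assay, 3-methylphenyl in place of 2-methylphenyl gives a 1.2-fold lower number from compound 1 to compound 3 (0.09 log units; within the scatter) and leaves the number within the scatter. Both methylphenyl groups therefore read alike here, so this change does not separate compounds in the series the way a 2.6-fold lower number from compound 1 to compound 2 (0.42 log units; beyond the scatter) does. Nothing at hand explains the result.

Still open, going by these compounds, is whether 4-methylphenyl, unsubstituted phenyl or a longer chain at this place would give a step beyond the scatter. Also open, on these data alone, is whether 3-methylphenyl reads the same on the core of compound 2.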